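Swapping the 1H-indol-1-yl group on a sulfonyl sulfur

The compounds below may be only part of what the source reports. "The series", "measured", "known", "first", "only" and "open" are said of these compounds alone.

Three compounds sharing a core have readings so far: compound 1 (`Cn1nc(C(F)(F)F)cc1C(=O)Nc1ccc(S(=O)(=O)N2CCC[C@H]2C(=O)OC(=O)c2ccccc2)cc1`), compound 2 (`Cn1nc(C(F)(F)F)cc1C(=O)Nc1ccc(S(=O)(=O)n2ccc3ccccc32)cc1`) and compound 3 (`Cn1nc(C(F)(F)F)cc1C(=O)Nc1ccc(S(=O)(=O)N2CCN(C(=O)OC(C)(C)C)CC2)cc1`). In an ADME assay on Vero cells (Chlorocebus sabaeus) for cytotoxicity, read by MTT assay (on this read-out higher numbers stand for lower toxicity in this test and lower numbers for higher toxicity in this test), compound 1 gives 100000 nM and compound 2 gives 13000 nM as its reading. Compound 3 reads > 300000 nM and this is a limit of the assay, not a number. Compound 2 therefore holds the lower of the two numbers, beyond the scatter from compound 1.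

Compound 4 (`Cn1nc(C(F)(F)F)cc1C(=O)Nc1ccc(S(=O)(=O)N2CCCCC2CO)cc1`) differs from compound 2 in one place (2-(hydroxymethyl)piperidin-1-yl in place of 1H-indol-1-yl on a sulfonyl sulfur), with 2-(hydroxymethyl)piperidin-1-yl in place of 1H-indol-1-yl on a sulfonyl sulfur. Compound 1, which likewise carries no 1H-indol-1-yl group there, stands at 100000 nM in this assay and so points to an expected rise in the number. The estimated step of a 6.2-fold higher number from compound 2 to compound 4 (0.79 log units; beyond the scatter) is expected to lie beyond the scatter, toward lower toxicity in this test. Compound 4 is estimated at 80000 nM within an expected range of 25000 nM to 250000 nM when measured.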

Compound 4, half-maximal cytotoxic concentration: 159000 nM
Compound 4: middle estimate off by 2.0-fold (0.30 log units), on the low side; low and high end bracket the measured number.
By their numbers in this assay, from the lowest: compound 2; then compounds 1 and 4 (each within the scatter of the next). At a limit, above all of these: compound 3.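

In this assay, going by these compounds alone, the earlier compounds offered no step between compounds differing in one place; now the change on the sulfonyl sulfur gives a 12-fold higher number from compound 2 to compound 4 (1.09 log units; beyond the scatter), a large move toward lower toxicity in this test. Thus, 2-(hydroxymethyl)piperidin-1-yl in place of 1H-indol-1-yl shifts the reading well beyond the scatter, leaving compound 2, the only compound shown with the 1H-indol-1-yl group, with the lowest number. Compound 3 reads at a limit of the assay, not a number: the limit of > 300000 nM in this assay, at which 1 of the 4 values shown sits.

The ring change and the hydroxymethyl group arrive together, so the compounds shown do not tell which of them carries the step. A plain piperidin-1-yl group or an indolin-1-yl group on the same sulfur would separate the two.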